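The compounds below may be only part of what the source reports. "The series", "measured", "known", "first", "only" and "open" are said of these compounds alone.

For the measured compounds named here, in an assay on isolated protein for agonist activity at Bile acid receptor (Homo sapiens), read by AlphaScreen, with a stated time of 30 min (a lower number here means that less compound is needed, a higher number that more compound is needed for the effect), compound 3 `COc1ccccc1Oc1ccc([C@H]2S[C@@H](C)C(=O)Nc3c2c(C)nn3-c2ccccc2C)cc1` gives 1700 nM, while compound 2 `Cc1ccccc1-n1nc(C)c2c1NC(=O)[C@H](C)S[C@@H]2c1ccc(-c2ccsc2)cc1` gives 1400 nM; the only single-change step among the measured compounds, a 1.2-fold higher number from compound 2 to compound 3 (0.08 log units; within the scatter), falls within the scatter. Compound 1 `Cc1ccccc1-n1nc(C)c2c1NC(=O)[C@H](C)S[C@@H]2c1ccc(/C=C/c2ccccc2)cc1` is reported as "not active" (no number reported). Compound 3 thus holds the highest of the two numbers, but stands no farther from compound 2 than repeated measurements usually stray. Compound 4 `Cc1ccccc1-n1nc(C)c2c1NC(=O)[C@H](C)S[C@@H]2c1ccc(OCc2ccccc2)cc1` differs from compound 3 in one place: benzyl in place of 2-methoxyphenyl on an oxygen on an aromatic ring. The measured step swapped a different group and stayed within the scatter, so it offers only weak guidance for this new change. A step no larger than the scatter is therefore expected, no change at the digits printed from compound 3 to compound 4 (within the scatter). Compound 4 is estimated at 1700 nM, with a range from 600 nM to 5000 nM.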

Compound 4, half-maximal effective concentration: "not active" (no number reported)
Nothing numeric was reported for compound 4; there is nothing to compare the estimate with.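

In this assay compound 4 gives "not active" (no number reported) without a number, so no step from compound 3 can be read, and nothing shown here explains the result. Going by these compounds, how much of compound 1 or compound 4 would be needed for any effect stays open.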